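Replacing 2-chlorophenyl with a non-aromatic group

A few compounds are considered here, and "the series" means these few. Any claim that something is new, unique, unknown or untested is made for them only; others in the source may bear on it.

Measured in an ADME assay on microsomes from liver (Mus musculus) for metabolic stability, with a stated time of 10 min, tested at 0.5 uM; a lower number here means that less of the compound is left, a higher number that more of the compound is left:
- Compound 1 `C[C@@H](NC(=O)Nc1ccc(Cl)cc1)[C@H]1CC[C@@H](c2ccnc3ccc(F)cc32)CC1`: 14%
- Compound 2 `C[C@@H](NC(=O)c1cccc(Cl)c1)[C@H]1CC[C@@H](c2ccnc3ccc(F)cc32)CC1`: 9%
- Compound 3 `C[C@@H](NC(=O)c1ccccc1Cl)[C@H]1CC[C@@H](c2ccnc3ccc(F)cc32)CC1`: 7%

In this assay, compound 3 gives 7% and cannot be told apart from compound 1 or compound 2, since all three values lie within the scatter of one another. Compound 4 `C[C@@H](NC(=O)C12CCC(Cl)(CC1)CC2)[C@H]1CC[C@@H](c2ccnc3ccc(F)cc32)CC1` differs from compound 3 in one place: a group of 9 heavy atoms (8 carbon, 1 chlorine; 2 six-membered non-aromatic rings of carbon only) in place of a group of 7 heavy atoms (6 carbon, 1 chlorine; one six-membered aromatic ring of carbon only), on a carbonyl carbon. The one six-membered aromatic ring of carbon only leaves, and 2 six-membered non-aromatic rings of carbon only enter.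

Three measured steps changed the group on this same carbonyl carbon: a number 5 percentage points lower from compound 1 to compound 2 (within the scatter), a number 7 percentage points lower from compound 1 to compound 3 (within the scatter) and a number 2 percentage points lower from compound 2 to compound 3 (within the scatter). None of them replaces an aromatic ring with non-aromatic rings, so they are only a loose guide, and the range must stay wide. Going by the small size of a number 7 percentage points lower from compound 1 to compound 3 (within the scatter), no step beyond the scatter is expected, and no direction can be favoured. The estimated change is a number 5 percentage points higher from compound 3 to compound 4 (within the scatter). For compound 4 the estimated value is 12%, with an expected range from 3% to 30%.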

Compound 4, percent of the compound remaining: 10%
Compound 4: middle estimate off by 2 percentage points, on the high side; the range from low to high includes it.
By their numbers in this assay, from the lowest: compounds 3, 2, 4 and 1 (each within the scatter of the next).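

Every earlier change on this carbonyl carbon kept a chlorophenyl ring, whereas this one removes the aromatic ring altogether, and the reading in this assay still shows only a number 3 percentage points higher from compound 3 to compound 4 (within the scatter). The comparisons with the other two compounds tell the same story, with a number 1 percentage points higher from compound 2 to compound 4 (within the scatter) and a number 4 percentage points lower from compound 1 to compound 4 (within the scatter), so aromatic and non-aromatic groups at this place cannot be told apart in these four compounds. No measurement shown explains why the readings stay so close.

On these data alone, it remains open whether a group of a different kind on this carbonyl carbon, such as an amine or a carboxylic acid, would give a step beyond the scatter. The part played by the chlorine is also open: every compound shown carries one, so a version of the new rings with hydrogen in its place would be needed to tell.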